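The compounds below may be only part of what the source reports. "The series", "measured", "known", "first", "only" and "open" are said of these compounds alone.

Of the compounds shown here, two built on one shared core have been tested so far: compound 1 `CC(C)n1ncc2c(NC(=O)c3ccc(F)cc3)cc(-c3cccs3)nc21` and compound 2 `CNS(=O)(=O)c1cccc(NC(=O)c2cc(-c3cccs3)nc3c2cnn3C(C)C)c1`. In an ADME assay on LLC-MK2 cells (Macaca mulatta) for cytotoxicity, read by spectrophotometry and crystal violet staining, with a stated time of 4 days (a higher number here means that more compound is tolerated, a lower number that less compound is tolerated), compound 1 gives 50000 nM. In the same test, compound 2 gives 25000 nM. These two numbers lie within the usual scatter of repeated measurements, so compound 2 cannot be ranked apart from compound 1.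

Still unmeasured is compound 3 `CC(C)n1ncc2c(C(=O)Nc3cccc(S(=O)(=O)N(C)C)c3)cc(-c3cccs3)nc21`, which differs from compound 2 in one small place: methyl in place of hydrogen on a sulfonamide nitrogen. Within the data shown here, no measured pair shows what such a change does in this assay, so the closest guide is compound 2 itself, at 25000 nM. For so small a change, no shift beyond the scatter is expected, and neither direction can be favoured. The estimated step is no change at the digits printed from compound 2 to compound 3 (within the scatter), which is expected to stay within the scatter. For compound 3 the estimated value is 25000 nM, with an expected range of 10000 nM to 50000 nM.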

Compound 3, half-maximal cytotoxic concentration: > 200000 nM
Compound 3 gave a limit, no number (the forecaster's own chance of this, stated with the estimate: 15%); middle value at least 8.0-fold (0.90 log units) away from the limit.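

Putting methyl in place of hydrogen on the sulfonamide nitrogen, which turns methylsulfamoyl into dimethylsulfamoyl, gives an at least 8.0-fold higher number from compound 2 to compound 3 (0.90 log units; beyond the scatter) in this assay. This is the first pair shown that differs in one place only, and it reveals that this nitrogen is a site where adding a single carbon can move the tolerated concentration beyond the usual scatter, a sensitivity that the comparison of compound 1 with compound 2 could not isolate. The value for compound 3 is a limit of the assay and not a number: the limit of > 200000 nM in this assay, at which 1 of the 3 values shown sits.

One pair cannot tell whether the result depends on the added methyl itself or on the loss of the hydrogen from that nitrogen, and it sets no general pattern for sulfonamides on this core. An ethyl group on the same nitrogen, or a morpholine ring built on it in place of both small substituents, would show whether the result holds for other groups at this position.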